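The compounds below may be only part of what the source reports. "The series", "measured", "known", "first", "only" and "open" are said of these compounds alone.

Compound 3, with the structure `CCOC(=O)c1cc(-c2cccc(OCc3cccc(OC)c3)c2)on1`, sits at the edge of what an ADME assay on Vero cells (Chlorocebus sabaeus) for cytotoxicity, with a stated time of 72 h (a lower number here means a stronger inhibitor, a higher number a weaker inhibitor), can report. In this assay compound 3 gives only the limit > 128000 nM, which is not a number. Compound 1, with the structure `CCOC(=O)c1cc(-c2cccc(OCc3cccc(C(F)(F)F)c3)c2)on1`, gives the same limit > 128000 nM in this assay. Compound 2, with the structure `CCOC(=O)c1cc(-c2cccc(OCc3cccc(OC(F)(F)F)c3)c2)on1`, gives a number in this assay, 101000 nM. Two of the three values therefore share one edge, as the limit of > 128000 nM in this assay, at which 2 of the 3 values shown sit, shows. The measured steps are small or unreadable: an at least 1.2-fold lower number from compound 1 to compound 2 (0.10 log units; that floor lies within the scatter), an at least 1.2-fold higher number from compound 2 to compound 3 (0.10 log units; that floor lies within the scatter), and a step that the two limits leave unreadable from compound 1 to compound 3. Compound 4, with the structure `CCOC(=O)c1cc(-c2cccc(OCc3cc(F)cc(F)c3)c2)on1`, differs from compound 3 by 3,5-difluorophenyl in place of 3-methoxyphenyl on a saturated chain carbon bound to an oxygen on an aromatic ring. All three measured compounds sit at or near the limit, so an expected step of about an at least 1.0-fold lower number from compound 3 to compound 4 (0.02 log units; that floor lies within the scatter) is the reasonable reading, with no change beyond the scatter foreseen. The estimate for compound 4 in this assay is 120000 nM, within the range 55000 nM to 260000 nM.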

Compound 4, half-maximal inhibitory concentration: > 128000 nM
Compound 4: no number, only a limit; the forecaster's own chance of this, stated with the estimate: 65%; at least 1.0-fold (0.02 log units) between middle value and limit.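

In this assay, among these compounds, compound 3 and compound 4 each give only a limit, not a number, so no step between them can be read. The compounds shown leave open whether 3,5-difluorophenyl in place of 3-methoxyphenyl changes the true value at all, since the readings stop at one edge: the limit of > 128000 nM in this assay, at which 3 of the 4 values shown sit.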